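The compounds below may be only part of what the source reports. "The series", "measured", "known", "first", "only" and "open" are said of these compounds alone.

Series notes.

Compound 1 `O=C1/C(=C/c2ccccc2Cl)CCc2c(O)cccc21` and compound 2 `O=C1/C(=C/c2ccccc2Br)CCc2c(O)cccc21` share one core; compound 3 `O=C1/C(=C/c2cccc(Cl)c2)CCc2ccc(O)cc21` and compound 4 `O=C1/C(=C/c2cccc(Br)c2)CCc2ccc(O)cc21` share another. In a functional assay on RAW264.7 cells (Mus musculus) for inhibition (a higher number here means a weaker inhibitor, a lower number a stronger inhibitor), compound 1 gives 1280 nM, and compound 2 gives 1240 nM. The step of a 1.0-fold lower number from compound 1 to compound 2 (0.01 log units; within the scatter) comes with the change (bromo in place of chloro on an aromatic carbon). In this assay compound 3 gives 210 nM, the lowest number of the three measured, with the nearest of the other two, compound 2, at a gap beyond the scatter. The difference between the core of compound 3 and the core of compound 1 is not broken down here.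

Compound 4 carries the change (bromo in place of chloro on an aromatic carbon). For the measured compounds named here, this is the same kind of change as the one from compound 1 to compound 2, but not the same: there the place was ortho to a large group, here it is meta to a large group. Going by the values given here, the only measured instance of bromo in place of chloro is the step from compound 1 to compound 2, which sits within the scatter, so the expected step of no change at the digits printed from compound 3 to compound 4 (within the scatter) is set beside it and rests on that single pair; with no measured bromo analogue on the core of compound 3, the spread is kept wide. In this assay compound 4 is estimated at 210 nM, expected to fall between 100 nM and 450 nM.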

Compound 4, half-maximal inhibitory concentration: 480 nM
For compound 4 the middle estimate is 2.3-fold (0.36 log units) below the measured one; the whole stated range lies below it.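

On the core of compound 3, bromo in place of chloro gives, in this assay, a 2.3-fold higher number from compound 3 to compound 4 (0.36 log units; beyond the scatter), a modest step that points toward weaker inhibition. Set beside the earlier step on the core of compound 1, which stays within the scatter, this gives no firm sign that the change behaves differently on the two cores: the same change on two cores in this assay, a 1.0-fold lower number (0.01 log units; within the scatter) from compound 1 to compound 2 and a 2.3-fold higher number (0.36 log units; beyond the scatter) from compound 3 to compound 4, 2.4-fold (0.37 log units) apart, within the scatter of two such steps. For the compounds shown here, this does not show that the change carries over unaltered either, since the comparison rests on only two pairs, and the two pairs differ both in the core and in the place of the halogen, so any effect of the core cannot be separated from that of the place.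

The compounds shown leave open whether the step seen with bromo extends to other groups at the place meta to a large group on the core of compound 3, such as fluoro, iodo, methyl, methoxy, trifluoromethyl or nitrile. They also leave open how an amine or a carboxylic acid would read at that place, and whether any such replacement would give the same step on the core of compound 1.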